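A few compounds are considered here, and "the series" means these few. Any claim that something is new, unique, unknown or untested is made for them only; others in the source may bear on it.

Working notes on the series.

Compound 1 `Cc1cc(C(=O)O)ccc1OCCCCOc1ccc(C(=O)C(C)C)c(O)c1C` is the parent of the first pair; in an assay on HEK293 cells for positive allosteric modulation of metabotropic glutamate receptor 2 (Rattus norvegicus), read by thallium flux, with a stated time of 2.5 min (on this read-out lower numbers stand for smaller maximal responses and higher numbers for larger maximal responses), compound 1 gives 76.9%. Compound 2 `CC(=O)c1ccc(OCCCCOc2ccc(C(=O)O)cc2C)c(C)c1O` differs from compound 1 in a single place, (methyl in place of isopropyl on a carbonyl carbon), and in this assay compound 2 gives 83.1%. The change made a number 6.2 percentage points higher from compound 1 to compound 2 (within the scatter), so the two values cannot be told apart by this measurement.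

Compound 3 `Cc1c(OCCCCOc2ccc(F)c(C(=O)O)c2)ccc(C(=O)C(C)C)c1O` stands on a different core; the difference between the core of compound 1 and the core of compound 3 is not broken down here. In this assay compound 3 gives 74.1%, a value that lies within the scatter of both compound 1 and compound 2, so none of the three measured compounds can be ranked against the others.

Compound 4 `CC(=O)c1ccc(OCCCCOc2ccc(F)c(C(=O)O)c2)c(C)c1O` is not yet measured. It differs from compound 3 as methyl in place of isopropyl on a carbonyl carbon, the same change that was made from compound 1 to compound 2, at the same place, a carbonyl carbon whose other neighbour is an aromatic carbon. The step is expected to be a number 5.9 percentage points higher from compound 3 to compound 4 (within the scatter) in this assay, the expectation resting on compound 1, because the same change on its core gave a number 6.2 percentage points higher from compound 1 to compound 2 (within the scatter), a step that stayed within the scatter. Compound 4 is therefore estimated to give 80% in this assay, with the expected range running from 70% to 90%.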

Compound 4, largest response reached (reported as percent of maximum), in percent of the reference or control that the assay uses: 75.5%
The estimate for compound 4 lay 4.5 percentage points above the measured number; low and high end bracket the measured number.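

Replacing isopropylcarbonyl with acetyl on the core of compound 3 gives, in this assay, a number 1.4 percentage points higher from compound 3 to compound 4 (within the scatter), so the two values cannot be told apart. Set beside the earlier step, the same change on a carbonyl carbon shows no measurable difference in size between the two cores: the same change on two cores in this assay, a number 6.2 percentage points higher (within the scatter) from compound 1 to compound 2 and a number 1.4 percentage points higher (within the scatter) from compound 3 to compound 4, 4.8 percentage points apart, within the scatter of two such steps. This shows that on these two cores the swap of isopropyl for methyl leaves the maximal response within the scatter, and that the step carries from one core to the other as far as this read-out can tell; it does not show that the change has any real effect on either core, nor that the agreement would extend to a further core, since it rests on two pairs only.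

Still open, on these data alone, is whether a group larger than isopropyl on the carbonyl carbon, such as tert-butyl or phenyl, would move the maximal response beyond the scatter. Also open, as far as these compounds go, is whether the same change would stay as small with an amide or a tetrazole in place of the carboxylic acid, or with a longer chain joining the two aromatic parts.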